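Spiro pyranoquinoxaline oxindoles bearing triazolyl-linked aryl groups

This account rests on a few compounds, and the source may have more. Where it says the series, first, only, none or still open, it means among the compounds named here.

Compound 1 `N#CC1=C(N)Oc2c(c3nc4ccccc4nc3c3ccccc23)C12C(=O)N(Cc1cnnn1-c1ccccc1Cl)c1ccccc12` gives 42600 nM in a functional assay on A549 cells (Homo sapiens) for antiproliferative activity, read by MTT assay, with a stated time of 48 h; on this read-out lower numbers stand for stronger inhibition and higher numbers for weaker inhibition.
Compound 2 `N#CC1=C(N)Oc2c(c3nc4ccccc4nc3c3ccccc23)C12C(=O)N(Cc1cnnn1-c1ccc(Cl)c(Cl)c1)c1ccccc12` gives > 50000 nM, a limit of this assay.
Compound 3 `N#CC1=C(N)Oc2c(N)cc3nc4ccccc4nc3c2C12C(=O)N(Cc1cnnn1-c1ccc(F)cc1)c1ccccc12` gives > 50000 nM, also a limit of this assay.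

Compound 3 therefore stands at the limit of this assay rather than at a number, and it shares that position with one other value shown (the limit of > 50000 nM in this assay, at which 2 of the 3 values shown sit). The unmeasured compound 4 `N#CC1=C(N)Oc2c(N)cc3nc4ccccc4nc3c2C12C(=O)N(Cc1cnnn1-c1cc(Cl)ccc1Cl)c1ccccc12` differs from compound 3 in one place: 2,5-dichlorophenyl in place of 4-fluorophenyl on an aromatic nitrogen.

Within the data shown here, only one measured step changes the aryl group on the aromatic nitrogen: an at least 1.1-fold higher number from compound 1 to compound 2 (0.06 log units; that floor lies within the scatter). That step is a floor set by a limit and lies within the scatter, so it gives no direction beyond the scatter. Compound 3 is itself at the limit, and compound 4 is expected to remain at or near that limit, with a step that the limit leaves unreadable from compound 3 to compound 4 as the expected step. Compound 4 is estimated at 60000 nM, within 25000 nM to 150000 nM, most likely reported again as a limit.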

Compound 4, half-maximal inhibitory concentration: 10900 nM
Compound 4: middle estimate off by 5.5-fold (0.74 log units), on the high side; the whole stated range lies above it.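

In this assay, 2,5-dichlorophenyl in place of 4-fluorophenyl on the aromatic nitrogen gives an at least 4.5-fold lower number from compound 3 to compound 4 (0.66 log units; beyond the scatter). This shows that the aryl group at this position can shift the read-out beyond the scatter, which the earlier step, an at least 1.1-fold higher number from compound 1 to compound 2 (0.06 log units; that floor lies within the scatter), could not show. The true size of the new step cannot be read, because compound 3 stands only at a limit of the assay: the limit of > 50000 nM in this assay, at which 2 of the 4 values shown sit.

The compounds shown leave open whether a single chlorine would be enough, as a 2-chlorophenyl or 3-chlorophenyl on the core of compound 3 would tell, and what a plain phenyl or a 4-methoxyphenyl would give there. From the compounds shown here alone, it also remains open whether 2,5-dichlorophenyl would produce a similar step on the core of compound 1.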